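This account rests on a few compounds, and the source may have more. Where it says the series, first, only, none or still open, it means among the compounds named here.

Of the compounds shown here, three of one shared family have been tested in an ADME assay on HepG2 cells (Homo sapiens) for cytotoxicity, read by MTT assay, with a stated time of 72 h; on this read-out higher numbers stand for lower toxicity in this test and lower numbers for higher toxicity in this test. Compound 1 `Fc1ccc(/C=N/c2sc3c(c2-c2nc4ccccc4s2)CCC3)cc1` gives 302 ug/mL in this assay. Compound 2 `Fc1ccccc1/C=N/c1sc2c(c1-c1nc3ccccc3s1)CCC2` gives 394 ug/mL. The only single-point change among these two is a 1.3-fold higher number from compound 1 to compound 2 (0.12 log units; within the scatter), so the move from one fluorine position to the other left the read-out essentially unchanged. Compound 3 `Clc1ccc(/C=N/c2sc3c(c2-c2nc4ccccc4s2)CCCC3)c(Cl)c1` gives 384 ug/mL, the second highest of the three numbers; its nearest neighbour is compound 2, and its most distant is compound 1, yet both gaps fall inside the ordinary spread of repeated tests, so nothing separates these three compounds in this assay.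

Compound 4 `C(=C/c1ccccc1)\C=N\c1sc2c(c1-c1nc3ccccc3s1)CCCC2` has not yet been tested. It differs from compound 3 by 2-phenylethenyl in place of 2,4-dichlorophenyl on a carbon with a double bond to nitrogen. For the measured compounds named here, no measured step swaps an aromatic ring for an alkene-bearing group, so the only guidance is indirect: the one measured step, from compound 1 to compound 2, changed nothing beyond the scatter, and every compound so far sits in the same narrow band. On that basis compound 4 is expected to stay close to compound 3, giving a step of a 1.1-fold lower number from compound 3 to compound 4 (0.04 log units; within the scatter) in this assay. The expected value for compound 4 is 350 ug/mL, with a range from 220 ug/mL to 560 ug/mL.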

Compound 4, half-maximal cytotoxic concentration: 467 ug/mL
The estimate for compound 4 lay 1.3-fold (0.13 log units) below the measured number; measured number inside the range.
By their numbers in this assay, from the lowest: compounds 1, 3, 2 and 4 (each within the scatter of the next).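

On a carbon with a double bond to nitrogen, replacing 2,4-dichlorophenyl with 2-phenylethenyl gives, in this assay, a 1.2-fold higher number from compound 3 to compound 4 (0.08 log units; within the scatter). For the compounds shown here, the one earlier step only moved a fluorine around a ring, whereas this one exchanges the whole group, losing both chlorine atoms and bringing in a double bond outside the aromatic ring, and the read-out still stays within the scatter, so this place accepts more than a shift of one substituent without a measurable change in this test. Nothing measured here explains why the number holds steady.

Going by these compounds alone, every group at this place so far is built on a six-membered aromatic ring of carbon only, so it remains open whether an amine, a carboxylic acid or a longer chain on this carbon would move the number beyond the scatter. Within the data shown here, the core of compound 1 also differs from the core of compound 3, and no pair differing in that one place alone shows what that difference does by itself.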